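A few compounds are considered here, and "the series" means these few. Any claim that something is new, unique, unknown or untested is made for them only; others in the source may bear on it.

Measured so far in a functional assay on P815 cells (Mus musculus) for antiproliferative activity; a lower number here means a stronger inhibitor, a higher number a weaker inhibitor:
compound 1, `Nc1nc(=O)n(C2OC(CO)C(I)C2O)cc1F`, 0.1 ug/mL
compound 2, `Cc1ccc(S(=O)(=O)O[C@@H]2[C@@H](O)[C@H](n3ccc(N)nc3=O)O[C@@H]2CO)cc1`, 0.06 ug/mL
compound 3, `Nc1ccn(C2OC(CO)C(Br)C2O)c(=O)n1`, 0.05 ug/mL

Compound 2 gives the second highest of the three numbers in this assay. Its nearest neighbour is compound 3, whose number is lower by a margin that lies within the scatter; the furthest is compound 1, whose number is higher, again within the scatter. Within the data shown here, on these three numbers no compound stands apart from the others, and no ordering among them can be read.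

The next compound, compound 4 `Cc1ccc(S(=O)(=O)O[C@@H]2[C@@H](O)[C@H](n3cc(F)c(N)nc3=O)O[C@@H]2CO)cc1`, is derived from compound 2 by a single change: fluoro in place of hydrogen on an aromatic carbon. The rest of compound 2 is kept unchanged. Compound 1 also carries a fluoro group on its core, and its number in this assay sits within the scatter of both compound 2 and compound 3, so the three measured numbers give no sign that the fluoro group shifts the read-out in either direction. The step of a 1.2-fold higher number from compound 2 to compound 4 (0.07 log units; within the scatter) is therefore expected to stay within the usual scatter of this assay. Compound 4 is estimated at 0.07 ug/mL, with a range from 0.03 ug/mL to 0.2 ug/mL.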

Compound 4, concentration for 50% inhibition: 0.02 ug/mL
Compound 4: middle estimate off by 3.5-fold (0.54 log units), on the high side, and the stated range ends above it.
By their numbers in this assay, from the lowest: compound 4; then compounds 3, 2 and 1 (each within the scatter of the next).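

In this assay, fluoro in place of hydrogen on an aromatic carbon, ortho to an amino group and two atoms from the ring nitrogen, gives a 3.0-fold lower number from compound 2 to compound 4 (0.48 log units; beyond the scatter). Among these compounds, this is the first step that can be read at a single place, since no earlier pair differed in one place only, and it shows that this position responds to the addition of one fluorine atom, with the rest of the structure kept unchanged. Nothing shown accounts for the size or direction of this modest step, so it stands as an observation only.

One pair leaves open whether the lower number is particular to fluoro or would also follow from chloro, methyl or a nitrile at this position, and whether an amine there would keep or lose it. It also remains open whether the change carries over to other parts of the series: compound 1 carries fluoro but has no partner among the compounds shown that differs from it by this change alone.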